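This account rests on a few compounds, and the source may have more. Where it says the series, first, only, none or still open, it means among the compounds named here.

Three compounds in this series share one core and differ only in the aryl group on a nitrogen on an aromatic ring. Compound 1 `CCOc1ccccc1Nc1nc(SCc2ccc(C(F)(F)F)cc2)nc2ccccc12` carries a 2-ethoxyphenyl there, compound 2 `FC(F)(F)c1ccc(CSc2nc(Nc3cccc(Cl)c3)c3ccccc3n2)cc1` a 3-chlorophenyl, and compound 3 `O=[N+]([O-])c1cccc(Nc2nc(SCc3ccc(C(F)(F)F)cc3)nc3ccccc23)c1` a 3-nitrophenyl. In a functional assay on MCF7 cells (Homo sapiens) for cytotoxicity, read by MTT assay, with a stated time of 72 h (on this read-out higher numbers stand for weaker inhibition and lower numbers for stronger inhibition), compound 2 gives 25100 nM. For compound 1 the result > 50000 nM is a limit of the assay, not a number. For compound 3 the result > 50000 nM is likewise only a limit. Compound 3 thus sits at the ceiling of what the assay reports, a position it shares with one other entry, as the limit of > 50000 nM in this assay, at which 2 of the 3 values shown sit, shows. The step from compound 2 reads an at least 1.9-fold higher number from compound 2 to compound 3 (0.29 log units; that floor lies within the scatter), and the step from compound 1 is a step that the two limits leave unreadable from compound 1 to compound 3.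

Compound 4 `COc1cc(Nc2nc(SCc3ccc(C(F)(F)F)cc3)nc3ccccc23)cc(OC)c1` has not been measured in this assay. The change from compound 3 is 3,5-dimethoxyphenyl in place of 3-nitrophenyl on a nitrogen on an aromatic ring. Within the data shown here, no measured step bears on this particular exchange: the two steps that reach compound 3 both end at a limit, and the only readable value, from compound 2, lies near the same ceiling. The writer therefore expects compound 4 to follow the same pattern, with a step of an at least 1.2-fold lower number from compound 3 to compound 4 (0.09 log units; that floor lies within the scatter) that is most likely not readable beyond the scatter. Compound 4 is estimated at 40000 nM, within a range from 15000 nM to 100000 nM, with a real chance that the assay again returns only a limit.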

Compound 4, half-maximal inhibitory concentration: 6990 nM
Estimate against measurement, compound 4: 5.7-fold (0.76 log units) above, outside the stated range (below it).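

In this assay, the aryl group on a nitrogen on an aromatic ring now proves able to shift the result clearly: 3,5-dimethoxyphenyl in place of 3-nitrophenyl gives an at least 7.1-fold lower number from compound 3 to compound 4 (0.85 log units; beyond the scatter), and in place of 2-ethoxyphenyl it gives an at least 7.1-fold lower number from compound 1 to compound 4 (0.85 log units; beyond the scatter). Among these compounds, the exchange for 3-chlorophenyl gives a 3.6-fold lower number from compound 2 to compound 4 (0.56 log units; beyond the scatter), and this is the first step with a real number at both ends and a size beyond the scatter, whereas the earlier readable steps offered only floors within it. The other two new steps remain floors because compound 1 and compound 3 each rest on a limit of the assay and not on a number: the limit of > 50000 nM in this assay, at which 2 of the 4 values shown sit.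

The step between compound 1 and compound 3 cannot be read, and the compounds shown do not tell whether the 3,5-dimethoxyphenyl needs both of its methoxy groups. They also leave open how an amine, a carboxylic acid or a longer chain in place of methoxy would read on this aryl group.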